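The source may report more compounds than this note shows. Statements on the series, on what has been measured and on what is new or still open speak of the compounds shown alone.

Measured compounds:
- compound 1, `Cn1nc2c(=O)n(CC3(O)CCN(Cc4ccc(-c5ccco5)cc4Cl)CC3)cnc2c1-c1ccc(CNC=O)cc1`: 20.9 nM
- compound 2, `Cn1cc(-c2ccc(CN3CCC(O)(Cn4cnc5c(-c6ccc(CN)cc6)n(C)nc5c4=O)CC3)c(Cl)c2)cn1`: 291 nM
- compound 3, `Cn1nc2c(=O)n(CC3(O)CCN(Cc4ccc(-c5ccc[nH]5)cc4Cl)CC3)cnc2c1-c1ccc(CN)cc1`: 193 nM

In an assay on isolated protein for inhibition of ubiquitin carboxyl-terminal hydrolase 7 (Homo sapiens), with stated times of 30 min and 2 h (a higher number here means a weaker inhibitor, a lower number a stronger inhibitor), compound 1 gives the lowest of the three numbers; compound 3 sits a clear distance above it, and compound 2 further still. Among the measured compounds shown here, the one single-point step available, a 1.5-fold lower number from compound 2 to compound 3 (0.18 log units; within the scatter), concerns the other end of the molecule and lies within the scatter, so it says nothing about the group changed here. Compound 4, `Cn1nc2c(=O)n(CC3(O)CCN(Cc4ccc(-c5ccco5)cc4Cl)CC3)cnc2c1-c1ccc(F)cc1`, differs from compound 1 by fluoro in place of (formylamino)methyl on an aromatic carbon. For the measured compounds named here, no measured pair isolates this change; compounds 1 and 3 differ at this same position but also elsewhere, so their values only show that compound 1 is the stronger of the two. Given that the group leaving carries a donor and an acceptor and the group entering carries none, a weakening beyond the scatter is expected, by about a 7.2-fold higher number from compound 1 to compound 4 (0.86 log units; beyond the scatter). Compound 4 is therefore estimated at 150 nM, with a range from 40 nM to 600 nM.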

Compound 4, half-maximal inhibitory concentration: 64.5 nM
Estimate against measurement, compound 4: 2.3-fold (0.37 log units) above, and the stated range covers the measured number.
By their numbers in this assay, from the lowest: compound 1; then compound 4; then compounds 3 and 2 (each within the scatter of the next).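

In this assay, the change from (formylamino)methyl to fluoro on the six-membered aromatic ring of carbon only, para to a large group, gives a 3.1-fold higher number from compound 1 to compound 4 (0.49 log units; beyond the scatter). Among the compounds shown here, this is the first reading of this position with the rest of the molecule held constant; the earlier compounds differed here only together with changes elsewhere. The step is beyond the scatter but modest, so replacing a group of 4 heavy atoms, with its hydrogen-bond donor and acceptor, by a single fluorine atom weakens inhibition only to a limited degree, and nothing measured here accounts for the size of that loss. Going by these compounds, whether hydroxymethyl, a nitrile or a carboxylic acid at this place would read closer to compound 1 or to compound 4 remains open. Also open, on these data alone, is whether the step would keep its size alongside the different groups that compound 2 and compound 3 carry elsewhere.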